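Replacing naphthalen-2-yl with (4-chlorophenyl)amino on a carbonyl carbon

The source may report more compounds than this note shows. Statements on the series, on what has been measured and on what is new or still open speak of the compounds shown alone.

In a functional assay on HT-29 cells (Homo sapiens) for inhibition, read by MTT assay, with a stated time of 48 h (on this read-out higher numbers stand for weaker inhibition and lower numbers for stronger inhibition), compound 1 `COc1ccc(-n2c(SCc3ccc(C)cc3)nnc2-c2cc(OC)c(OC)c(OC)c2)cc1` gives > 60000 nM as a limit of the assay and not a number. Compound 2 `COc1ccc(CSc2nnc(-c3cc(OC)c(OC)c(OC)c3)n2-c2ccc(OC)cc2)cc1` likewise gives > 60000 nM as a limit. Within the data shown here, compound 3 `COc1ccc(-n2c(SCC(=O)c3ccc4ccccc4c3)nnc2-c2cc(OC)c(OC)c(OC)c2)cc1` gives 53400 nM as the only actual number of the three. Compound 4 `COc1ccc(-n2c(SCC(=O)Nc3ccc(Cl)cc3)nnc2-c2cc(OC)c(OC)c(OC)c2)cc1` has (4-chlorophenyl)amino in place of naphthalen-2-yl on a carbonyl carbon. The measured steps that bear on this change are an at least 1.1-fold lower number from compound 1 to compound 3 (0.05 log units; that floor lies within the scatter) and an at least 1.1-fold lower number from compound 2 to compound 3 (0.05 log units; that floor lies within the scatter) and neither floor lies beyond the scatter. They set no direction, so no step beyond the scatter is expected in this assay here. The expected step is a 1.5-fold lower number from compound 3 to compound 4 (0.18 log units; within the scatter) and no larger. Compound 4 is estimated at 35000 nM (expected range 6000 nM to 60000 nM).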

Compound 4, half-maximal inhibitory concentration: 58000 nM
Compound 4: middle estimate off by 1.7-fold (0.22 log units), on the low side; the measured number falls inside the stated range.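

In this assay, putting (4-chlorophenyl)amino in place of naphthalen-2-yl on the carbonyl carbon gives a 1.1-fold higher number from compound 3 to compound 4 (0.04 log units; within the scatter), so this change, which brings in a hydrogen-bond donor, separates the two compounds by no readable amount. The floors against the earlier limits, an at least 1.0-fold lower number from compound 2 to compound 4 (0.01 log units; that floor lies within the scatter) and an at least 1.0-fold lower number from compound 1 to compound 4 (0.01 log units; that floor lies within the scatter), add no separation either. This flat picture is read close to the edge of the assay's range: the limit of > 60000 nM in this assay, at which 2 of the 4 values shown sit. As far as these compounds go, whether a carboxylic acid, an amine or a longer chain on the carbonyl carbon would give a step beyond the scatter remains open.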